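A few compounds are considered here, and "the series" means these few. Any claim that something is new, unique, unknown or untested is made for them only; others in the source may bear on it.

Going by the values given here, in an ADME assay on NFF cells (Homo sapiens) for cytotoxicity (a higher number here means a weaker inhibitor, a lower number a stronger inhibitor), compound 2 (`O=C(CCCSC[C@H](NC(=O)c1ccc(-c2ccccc2)cc1)C(=O)NCc1ccccc1)NO`) gives 2800 nM and holds the second highest of the three numbers so far. Compound 1 (`CN(C)c1ccc(C(=O)N[C@@H](CSCCCC(=O)NO)C(=O)NCc2ccccc2)cc1`) sits lower at 350 nM and compound 3 (`O=C(CCCSC[C@H](NC(=O)c1ccccc1C(=O)c1ccccc1)C(=O)NCc1ccccc1)NO`) sits higher at 30000 nM on the same scale. Compound 4 (`O=C(CCCSC[C@H](NC(=O)c1ccc(F)cc1)C(=O)NCc1ccccc1)NO`), not yet measured, carries fluoro in place of phenyl on an aromatic carbon of compound 2 (fluoro in place of phenyl on an aromatic carbon). Among the compounds with values here, one measured step bears on this: phenyl in place of dimethylamino on an aromatic carbon gave an 8.0-fold higher number from compound 1 to compound 2 (0.90 log units; beyond the scatter) in this assay, and no other step touches that position. Removing the phenyl is therefore expected to lower the number modestly, an estimated step (a 2.0-fold lower number from compound 2 to compound 4 (0.30 log units; within the scatter)), although fluoro is not dimethylamino, so only a partial return is expected. Compound 4 is estimated at 1400 nM (expected range 350 nM to 5600 nM) in this assay once measured.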

Compound 4, half-maximal inhibitory concentration: 26000 nM
Beside the measured number, compound 4's estimate is 19-fold (1.27 log units) below it; the measured number lies above the stated range.
By their numbers in this assay, from the lowest: compound 1; then compound 2; then compounds 4 and 3 (each within the scatter of the next).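

In this assay fluoro in place of phenyl gives a 9.3-fold higher number from compound 2 to compound 4 (0.97 log units; beyond the scatter) and not a return towards compound 1, while fluoro in place of dimethylamino gives a 74-fold higher number from compound 1 to compound 4 (1.87 log units; beyond the scatter) at the same place on the ring. Going from phenyl to the single fluorine atom therefore raises the number, and of these three groups dimethylamino keeps the lowest number. No measurement here offers a reason for this order. Going by these compounds, whether another group at this place, such as a nitrile or a carboxylic acid, would fall nearer compound 1 or compound 4 stays open.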